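The source may report more compounds than this note shows. Statements on the series, on what has been measured and on what is new or still open speak of the compounds shown alone.

Measured so far in a functional assay on K562 cells (Homo sapiens) for inhibition, read by trypan blue exclusion, with a stated time of 72 h; a lower number here means a stronger inhibitor, a higher number a weaker inhibitor:

- compound 1 (`Cn1c(=O)c(S(=O)(=O)c2ccc(F)cc2F)cc2cnc(Nc3ccc4[nH]c(C(=O)O)cc4c3)nc21`) gives 10000 nM
- compound 2 (`Cn1c(=O)c(S(=O)(=O)c2ccc(F)cc2F)cc2cnc(Nc3ccc4c(c3)CC(=O)N4)nc21`) gives 15000 nM
- compound 3 (`Cn1ccc2cc(Nc3ncc4cc(S(=O)(=O)c5ccc(F)cc5F)c(=O)n(C)c4n3)ccc21`) gives 750 nM

Compound 3 has the lowest number of the three, which makes it the strongest inhibitor so far. The next candidate is compound 4 (`Cn1c(=O)c(S(=O)(=O)c2ccc(F)cc2F)cc2cnc(Nc3cnc4[nH]ccc4c3)nc21`). It keeps the shared core but replaces the 1-methyl-1H-indol-5-yl group, which sits on a nitrogen on an aromatic ring: a group of 9 heavy atoms (7 carbon, 2 nitrogen; one five-membered aromatic ring with 1 hetero atom, one six-membered aromatic ring with 1 hetero atom) in place of a group of 10 heavy atoms (9 carbon, 1 nitrogen; one five-membered aromatic ring with 1 hetero atom, one six-membered aromatic ring of carbon only), on a nitrogen on an aromatic ring.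

Two measured steps involve this same place, and both are large: a 13-fold lower number from compound 1 to compound 3 (1.12 log units; beyond the scatter) and a 20-fold lower number from compound 2 to compound 3 (1.30 log units; beyond the scatter). Between the other two groups there is little to separate: a 1.5-fold higher number from compound 1 to compound 2 (0.18 log units; within the scatter). So every other group tried so far gives a much weaker inhibitor, although neither matches the group entering here. A move to a higher number therefore seems likely, probably smaller than those two steps.

In this assay the expected step is a 4.0-fold higher number from compound 3 to compound 4 (0.60 log units; beyond the scatter). For compound 4 the estimated value is 3000 nM, with an expected range from 600 nM to 15000 nM.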

Compound 4, half-maximal inhibitory concentration: 750 nM
For compound 4 the middle estimate is 4.0-fold (0.60 log units) above the measured one; low and high end bracket the measured number.
By their numbers in this assay, from the lowest: compounds 3 and 4 (each within the scatter of the next); then compounds 1 and 2 (each within the scatter of the next).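

In this assay, the group with 1 hydrogen-bond donor and a six-membered aromatic ring with 1 hetero atom replaces 1-methyl-1H-indol-5-yl, with 0 hydrogen-bond donors, and this gives no change at the digits printed from compound 3 to compound 4 (within the scatter) on a nitrogen on an aromatic ring. The other comparisons, a 20-fold lower number from compound 2 to compound 4 (1.30 log units; beyond the scatter) and a 13-fold lower number from compound 1 to compound 4 (1.12 log units; beyond the scatter), show that the large gap seen at this place does not belong to 1-methyl-1H-indol-5-yl alone, since a second group now stands clear of the groups in compound 1 and compound 2. Nothing available explains these differences.

On these data alone, compound 3 and compound 4 differ in the methyl group and the ring nitrogen together, so the effect of each alone stays unknown. A plain phenyl group or an unmethylated 1H-indol-5-yl at this place would help to separate them.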